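This account rests on a few compounds, and the source may have more. Where it says the series, first, only, none or still open, it means among the compounds named here.

The measured compounds, all sharing one core:

Compound 1, `CNC(=O)/C=C/CNCCOc1ccc(Oc2c(-c3ccc(F)cc3)sc3cc(O)ccc23)cc1`, with 16100 nM in a functional assay on MCF7 cells (Homo sapiens) for antiproliferative activity, read by CCK-8 assay, with a stated time of 48 h; a lower number here means a stronger inhibitor, a higher number a weaker inhibitor.
Compound 2, `O=C(/C=C/CN1CC(Oc2ccc(Oc3c(-c4ccc(F)cc4)sc4cc(O)ccc34)cc2)C1)N1CCCC1`, with 8450 nM in this assay.
Compound 3, `C/C=C/C(=O)NCCOc1ccc(Oc2c(-c3ccc(F)cc3)sc3cc(O)ccc23)cc1`, with 21700 nM in this assay.

Compound 3 gives the highest number of the three. Going by the values given here, compound 1 lies nearest, within the scatter, and the single measured step, a 1.3-fold higher number from compound 1 to compound 3 (0.13 log units; within the scatter), is too small to count. Among the compounds with values here, compound 2 lies furthest away, with a lower number beyond the scatter; no single-point step links it to compound 3, so only the two values themselves speak.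

Compound 4, `C=CC(=O)N1CC(Oc2ccc(Oc3c(-c4ccc(F)cc4)sc4cc(O)ccc34)cc2)C1`, has not yet been measured. It differs from compound 3 in one place: 1-(vinylcarbonyl)azetidin-3-yl in place of 2-(((prop-1-en-1-yl)carbonyl)amino)ethyl on an oxygen on an aromatic ring. The step from compound 1 to compound 3 alters the chain-borne amide and moves nothing, so it says little here. Within the data shown here, compound 2, which carries the same azetidin-3-yl oxygen link as compound 4 but a different amide, sits below compound 3 in this assay, and that is the only guide to the direction. On this basis compound 4 is expected to give a lower number than compound 3, an estimated step of a 3.1-fold lower number from compound 3 to compound 4 (0.49 log units; beyond the scatter), with 7000 nM as the central estimate and a range from 3000 nM to 16000 nM. The certainty is modest, since compound 2 alone supports the expectation.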

Compound 4, half-maximal inhibitory concentration: 23500 nM
Compound 4: middle estimate off by 3.4-fold (0.53 log units), on the low side; the whole stated range lies below it.
By their numbers in this assay, from the lowest: compounds 2, 1, 3 and 4 (each within the scatter of the next, the first and the last beyond it).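

On an oxygen on an aromatic ring, this was the first direct test of 1-(vinylcarbonyl)azetidin-3-yl in place of 2-(((prop-1-en-1-yl)carbonyl)amino)ethyl, and in this assay the exchange lies within the scatter (a 1.1-fold higher number from compound 3 to compound 4 (0.03 log units; within the scatter)). The wider exchange at the same oxygen, which replaces the amine-bearing chain of compound 1 with the same azetidine group, also stays within the scatter (a 1.5-fold higher number from compound 1 to compound 4 (0.16 log units; within the scatter)). The azetidin-3-yl oxygen link therefore does not by itself give the lower number of compound 2: with that link held constant, vinylcarbonyl in place of 3-((pyrrolidin-1-yl)carbonyl)prop-2-en-1-yl on the ring nitrogen gives a modest step beyond the scatter (a 2.8-fold higher number from compound 2 to compound 4 (0.44 log units; beyond the scatter)). Nothing shown gives a reason for these numbers.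

The compounds shown leave open which part of the 3-((pyrrolidin-1-yl)carbonyl)prop-2-en-1-yl group goes with the lower number of compound 2. They also leave open how the number would respond to a saturated propanoyl group on the azetidine nitrogen, or to a piperidin-4-yl ring on the same oxygen.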